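The source may report more compounds than this note shows. Statements on the series, on what has been measured and on what is new or still open speak of the compounds shown alone.

Two compounds that share a core were tested in a functional assay on MCF7 cells (Homo sapiens) for antiproliferative activity, read by MTT assay, with a stated time of 72 h; a higher number here means a weaker inhibitor, a lower number a stronger inhibitor. For the measured compounds named here, compound 1 `COc1ccc(/C=C2/CN(C)/C(=N/c3ccc(F)cc3)S2)cc1` gives 8000 nM, the lower of the two numbers measured so far. Compound 2 `COc1ccc(/C=C2\S/C(=N\c3ccc(F)cc3)N(C)C2=O)cc1` gives 66500 nM, a higher number whose gap to compound 1 lies beyond the usual scatter. Compound 3 `COc1ccc(/C=C2/CN(C)/C(=N/c3ccc(C(F)(F)F)cc3)S2)cc1` has not yet been measured in this assay. It differs from compound 1 by trifluoromethyl in place of fluoro on an aromatic carbon. Going by the values given here, no step of this kind has been measured here, so the expected step of a 1.2-fold lower number from compound 1 to compound 3 (0.09 log units; within the scatter) is small, with no clear direction beyond the scatter. In this assay compound 3 is estimated at 6500 nM, within a range from 1800 nM to 24000 nM.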

Compound 3, half-maximal inhibitory concentration: 24100 nM
Compound 3: middle estimate off by 3.7-fold (0.57 log units), on the low side; measured number outside the range, above it.
By their numbers in this assay, from the lowest: compound 1; then compound 3; then compound 2.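

In this assay, trifluoromethyl in place of fluoro on this aromatic carbon, para to a large group, gives a 3.0-fold higher number from compound 1 to compound 3 (0.48 log units; beyond the scatter). The position therefore responds to this change: the group with four heavy atoms gives a weaker inhibitor than fluoro, with its single heavy atom, though the step is modest. No measurement shown here accounts for this difference.

With only these two groups compared at this position, no trend can be drawn. On these data alone, whether chloro or an amine there would give a lower or higher number remains open.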